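This account rests on a few compounds, and the source may have more. Where it says the series, first, only, none or still open, it means among the compounds named here.

For the measured compounds named here, in an ADME assay on cells (Macrophage, Mus musculus) for cytotoxicity, read by resazurin assay, with a stated time of 3 days (a lower number here means a stronger inhibitor, a higher number a weaker inhibitor), three related compounds have numbers so far. Compound 1 `COc1ccc(O)c(C(=O)Nc2cc(C(F)(F)F)cc(C(F)(F)F)c2)c1` gives 7700 nM, compound 2 `O=C(Nc1ccc(C(F)(F)F)cc1)c1cc(Cl)ccc1O` gives 2800 nM, and compound 3 `O=C(Nc1ccc(C(F)(F)F)c(C(F)(F)F)c1)c1cc(Cl)ccc1O` gives 4900 nM. Compound 2 therefore stands level with compound 3 within the usual scatter, while the number for compound 1 lies beyond the scatter on the higher side of compound 2.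

Compound 4 `O=C(Nc1ccc(F)cc1)c1cc(Cl)ccc1O` has not yet been measured. It differs from compound 2 at a single place: fluoro in place of trifluoromethyl on an aromatic carbon. The change is fluoro in place of trifluoromethyl on an aromatic carbon, para to a large group.

Going by the values given here, only one measured step bears on this change, the one that puts a trifluoromethyl in place of hydrogen on an aromatic carbon: a 1.8-fold higher number from compound 2 to compound 3 (0.24 log units; within the scatter). It is a different swap, so it is only a rough guide, but it suggests that no step beyond the scatter should be expected here. The expected step is a 1.4-fold higher number from compound 2 to compound 4 (0.15 log units; within the scatter). Compound 4 is therefore estimated at 4000 nM, with an expected range from 1700 nM to 10000 nM.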

Compound 4, half-maximal inhibitory concentration: 17000 nM
For compound 4 the middle estimate is 4.3-fold (0.63 log units) below the measured one; measured number above the stated range.
By their numbers in this assay, from the lowest: compounds 2, 3 and 1 (each within the scatter of the next, the first and the last beyond it); then compound 4.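

Putting fluoro in place of trifluoromethyl at this ring carbon, para to a large group, gives a 6.1-fold higher number from compound 2 to compound 4 (0.78 log units; beyond the scatter) in this assay and shows that the number responds to what sits at this place. For the compounds shown here, the one earlier step, a 1.8-fold higher number from compound 2 to compound 3 (0.24 log units; within the scatter), kept the trifluoromethyl of compound 2 and gave no sign of this, so the loss of that group is the first single change here to move the number beyond the scatter. Nothing given here explains the size of this step.

The compounds shown leave open whether fluoro itself matters or only the absence of trifluoromethyl, since none of them carries plain hydrogen at this place. They also leave open how a nitrile, an amine or a carboxylic acid would compare there.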